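The source may hold more compounds than are shown below. What is called first, only, known or untested is meant among the compounds shown, and "the series" means these compounds.

Measured in an ADME assay on HepG2 2.2.15 cells (Homo sapiens) for cytotoxicity; a higher number here means that more compound is tolerated, a lower number that less compound is tolerated:
- compound 1 `CC(=O)OCCc1c(-c2ccccc2Cl)c2cc(Cl)ccc2[nH]c1=O` gives 27000 nM
- compound 2 `O=C(OCCc1c(-c2ccccc2Cl)c2cc(Cl)ccc2[nH]c1=O)c1ccc([N+](=O)[O-])cc1` gives 1600000 nM
- compound 3 `O=C(CCOc1ccccc1)OCCc1c(-c2ccccc2Cl)c2cc(Cl)ccc2[nH]c1=O` gives 46000 nM

Compound 3 stands with compound 1 at the low end of these numbers (step: a 1.7-fold higher number from compound 1 to compound 3 (0.23 log units; within the scatter)) and well apart from compound 2 (step: a 35-fold lower number from compound 2 to compound 3 (1.54 log units; beyond the scatter)).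

Compound 4 `COc1ccc(/C=C/C(=O)OCCc2c(-c3ccccc3Cl)c3cc(Cl)ccc3[nH]c2=O)cc1OC` carries 2-(3,4-dimethoxyphenyl)ethenyl in place of 2-phenoxyethyl on a carbonyl carbon.

All three measured steps change the group at this same carbonyl carbon. Only 4-nitrophenyl gave a large move (step: a 59-fold higher number from compound 1 to compound 2 (1.77 log units; beyond the scatter)), while the step to the 2-phenoxyethyl group stayed small. The entering group is a chain bearing an aromatic ring, as 2-phenoxyethyl is, so compound 3 is the closer reference.

In this assay the expected step is none beyond the scatter (estimated: a 1.3-fold higher number from compound 3 to compound 4 (0.12 log units; within the scatter)). The upper range is kept wide with compound 2 in view (value: 1600000 nM). Compound 4 is estimated at 60000 nM, with an expected range from 18000 nM to 400000 nM.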

Compound 4, half-maximal cytotoxic concentration: > 1200000 nM
Compound 4 gave a limit, no number (the forecaster's own chance of this, stated with the estimate: 10%); at least 20-fold (1.30 log units) between middle value and limit.
By their numbers in this assay, from the lowest: compounds 1 and 3 (each within the scatter of the next); then compound 2.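

In this assay compound 4 gives > 1200000 nM, which is a limit and not a number. This carbonyl carbon now shows a second large move, an at least 26-fold higher number from compound 3 to compound 4 (1.41 log units; beyond the scatter) and an at least 44-fold higher number from compound 1 to compound 4 (1.64 log units; beyond the scatter), so a large rise is no longer tied to 4-nitrophenyl alone. The leaving 2-phenoxyethyl and the entering 2-(3,4-dimethoxyphenyl)ethenyl each carry one six-membered aromatic ring of carbon only, so that ring alone does not set the number, and the step between compound 2 and compound 4 cannot be read.

Open, going by these compounds, is whether the double bond or the methoxy groups carry the step. A plain 2-phenylethenyl or a saturated 2-(3,4-dimethoxyphenyl)ethyl chain at this carbonyl carbon would separate the two, and the data give no reading for either.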